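Benzyl ester in place of tert-butyl on the shared core

The compounds below may be only part of what the source reports. "The series", "measured", "known", "first", "only" and "open" are said of these compounds alone.

Measured compounds:
compound 1 `CCCOC(=O)C1=C(C)N(C)C(=O)NC1c1cccs1`: 1%
compound 2 `CC1=C(C(=O)OCC(C)C)C(c2cccs2)NC(=O)N1C`: 2%
compound 3 `CC1=C(C(=O)OC(C)(C)C)C(c2cccs2)NC(=O)N1C`: 24%

Three esters of the shared core have been measured in an assay on membranes from HEK293 cells for displacement of a labelled ligand from adenosine receptor A2b (Homo sapiens), read by scintillation counting, with a stated time of 30 min, tested at 1 uM; a lower number here means less inhibition, a higher number more inhibition at the concentration tested (going by the name of the read-out). Compound 1 gives 1% and compound 2 gives 2%; these two lie within the scatter of each other, as the step of a number 1 percentage points higher from compound 1 to compound 2 (within the scatter) shows. Compound 3 stands highest of the three, separated from both by steps beyond the scatter: a number 23 percentage points higher from compound 1 to compound 3 (beyond the scatter) and a number 22 percentage points higher from compound 2 to compound 3 (beyond the scatter). So far, then, the only change that has moved the read-out is the group on the oxygen next to the carbonyl group, and it has done so modestly.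

Compound 4 `CC1=C(C(=O)OCc2ccccc2)C(c2cccs2)NC(=O)N1C` differs from compound 3 in that same place: benzyl in place of tert-butyl on an oxygen next to a carbonyl group. The two steps that bear on this, from compound 1 and from compound 2 to compound 3, were each of modest size, and both involved replacing an ester alkyl group with a different one. Among the measured compounds shown here, no measured compound carries an aromatic ring in this position, so the direction of the step to benzyl is not fixed by the data. The step of a number 9 percentage points lower from compound 3 to compound 4 (within the scatter) is therefore expected to be small, possibly within the scatter. Compound 4 is estimated to give 15%, with a range from 0% to 40%.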

Compound 4, a percentage reported as inhibition, at one concentration (the size of the read-out at that concentration, not a potency): 50%
The estimate for compound 4 lay 35 percentage points below the measured number; measured number above the stated range.
By their numbers in this assay, from the lowest: compounds 1 and 2 (each within the scatter of the next); then compound 3; then compound 4.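

In this assay, the change from tert-butyl to benzyl on the oxygen next to a carbonyl group gives a number 26 percentage points higher from compound 3 to compound 4 (beyond the scatter), so tert-butyl does not mark the upper end of what this position can give. Set against the other two esters, the same position shows a larger range: phenyl in place of isopropyl gives a number 48 percentage points higher from compound 2 to compound 4 (beyond the scatter), and phenyl in place of ethyl gives a number 49 percentage points higher from compound 1 to compound 4 (beyond the scatter), both on a saturated chain carbon bound to that oxygen. Among these four esters, the only one with a six-membered aromatic ring of carbon only stands highest, so the group on this oxygen can move the read-out much further than the alkyl esters alone showed.

The compounds shown leave open whether the rise depends on the aromatic ring alone or also on the single carbon joining it to the oxygen, a question that a phenyl ester, a phenethyl ester or a benzyl ester with a chlorine or methoxy group on its ring could address. As far as these compounds go, the read-out also remains a percentage at one concentration, so how potent compound 4 is stays unknown. No evidence is available here to explain the rise.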